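Methylene oxindole bromoacrylamides: thiophene to pyrrole swap

A few compounds are considered here, and "the series" means these few. Any claim that something is new, unique, unknown or untested is made for them only; others in the source may bear on it.

Measured so far:
compound 1, `C=C(Br)C(=O)Nc1ccc2c(c1)/C(=C/c1cccs1)C(=O)N2`: 210 nM
compound 2, `C=C(Br)C(=O)Nc1ccc2c(c1)/C(=C\c1cccs1)C(=O)N2`: 616 nM

Compound 1 stands at the lower of the two numbers in a functional assay on Jurkat cells (Homo sapiens) for antiproliferative activity, read by MTT assay, with a stated time of 72 h; a lower number here means a stronger inhibitor, a higher number a weaker inhibitor; its nearest neighbour is compound 2, reached by a 2.9-fold higher number from compound 1 to compound 2 (0.47 log units; beyond the scatter). Among the measured compounds shown here, the only measured step in this assay thus concerns drawn configuration alone, because of the fact that compounds 1 and 2 differ only in the configuration as drawn the two compounds are the same in every atom and bond, and the step is modest in size.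

Compound 3, `C=C(Br)C(=O)Nc1ccc2c(c1)/C(=C/c1ccc[nH]1)C(=O)N2`, keeps the configuration of compound 1 and changes only the aromatic ring on the exocyclic carbon: 1H-pyrrol-2-yl in place of thiophen-2-yl on a double-bonded chain carbon bound to a double-bonded ring carbon. The ring that leaves carries one hydrogen-bond acceptor and the ring that enters carries one hydrogen-bond donor, both five-membered with a single hetero atom. For the measured compounds named here, no measured step bears on an exchange of this ring, and the configuration step gives no guide to it. With nothing in the data pointing one way, the number for compound 3 is expected to stay close to that of compound 1, with a 1.1-fold lower number from compound 1 to compound 3 (0.02 log units; within the scatter) taken as small and its direction uncertain. Compound 3 is therefore estimated at 200 nM, within a range from 60 nM to 700 nM.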

Compound 3, half-maximal inhibitory concentration: 110 nM
The estimate for compound 3 lay 1.8-fold (0.26 log units) above the measured number, within the range that was stated.
By their numbers in this assay, from the lowest: compounds 3 and 1 (each within the scatter of the next); then compound 2.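

The exchange of thiophen-2-yl for 1H-pyrrol-2-yl on a double-bonded chain carbon bound to a double-bonded ring carbon gives a 1.9-fold lower number from compound 1 to compound 3 (0.28 log units; within the scatter) in this assay and so does not separate the two rings at this position. Among the compounds shown here, this is the first reading of the aromatic ring itself, since the earlier pair varied only the drawn configuration, and here a ring with a hydrogen-bond acceptor and a ring with a hydrogen-bond donor sit within the scatter of each other while the double bond stays drawn as in compound 1. For the compounds shown here, the configuration step a 2.9-fold higher number from compound 1 to compound 2 (0.47 log units; beyond the scatter) therefore remains the only step beyond the scatter, and no available evidence accounts for how the two rings compare.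

Open, going by these compounds, is whether furan-2-yl or phenyl on the same carbon would also stay within the scatter of compound 1 in this assay or would move the number beyond it. Also open, on these data alone, is whether the pyrrole ring would show a configuration step of similar size if the double bond of compound 3 were drawn the other way.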